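The source may hold more compounds than are shown below. What is called first, only, known or untested is meant among the compounds shown, and "the series" means these compounds.

Measured so far in a functional assay on the whole organism (strain albino) for inhibition, with Rattus norvegicus as the target, read by paw edema, with stated times of 30 min and 2 h, at a dose of 100 mg/kg by the oral route; a lower number here means less inhibition, a higher number more inhibition at the dose given (going by the name of the read-out):
- compound 1, `COc1ccc(C2CC(c3ccc(OC)c(OC)c3)=NN2)c(OC)c1`: compound 1 gives 39%
- compound 2, `COc1ccc(C2CC(c3ccc(OC)c(OC)c3)=NN2C(=O)CO[N+](=O)[O-])c(OC)c1`: compound 2 gives 48%
- compound 3, `COc1ccc(C2=NN(C(=O)CO[N+](=O)[O-])C(c3c(Cl)cccc3Cl)C2)cc1OC`: compound 3 gives 49%

Compound 2 stands second highest of the three numbers, but neither neighbour is separated from it beyond the scatter: the step of a number 9 percentage points higher from compound 1 to compound 2 (within the scatter) and the step of a number 1 percentage points higher from compound 2 to compound 3 (within the scatter) both fall within the usual spread of repeated measurements, so the three compounds are, on these numbers, indistinguishable.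

Compound 4, `COc1ccc(C2CC(c3ccc(OC)c(OC)c3)=NN2C(=O)C(C)Br)c(OC)c1`, is the next compound to be measured. Its change from compound 2 is 1-bromoethyl in place of (nitrooxy)methyl on a carbonyl carbon. Going by the values given here, no measured step exchanges one carbonyl substituent for another, so nothing bears on it directly. The nearest case is a number 9 percentage points higher from compound 1 to compound 2 (within the scatter), where the whole ((nitrooxy)methyl)carbonyl group was introduced onto the ring nitrogen and the read-out moved only within the scatter; the step of a number 1 percentage points higher from compound 2 to compound 3 (within the scatter), which alters a different part of the molecule, was likewise within the scatter. On this basis no step beyond the scatter is expected in either direction.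

Compound 4 is therefore estimated at 45%, with a range from 30% to 60%. The expected step is a number 3 percentage points lower from compound 2 to compound 4 (within the scatter), essentially flat.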

Compound 4, a percentage reported as inhibition, in the whole organism at one dose (the size of the read-out at that dose, not a potency): 63%
For compound 4 the middle estimate is 18 percentage points below the measured one; measured number above the stated range.
By their numbers in this assay, from the lowest: compounds 1, 2 and 3 (each within the scatter of the next); then compound 4.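

In this assay, going by these compounds alone, the group on the carbonyl carbon is the first place where a change carries the read-out beyond the scatter: with 1-bromoethyl in place of (nitrooxy)methyl, the result is (  a number 15 percentage points higher from compound 2 to compound 4 (beyond the scatter)  ), so this position is not indifferent, and the nitrooxy group is not required for the inhibition seen at this dose. The substituent on the ring nitrogen also now reads differently: introducing ((nitrooxy)methyl)carbonyl gave a step within the scatter (a number 9 percentage points higher from compound 1 to compound 2 (within the scatter)), whereas (1-bromoethyl)carbonyl in place of hydrogen gave a step beyond it (a number 24 percentage points higher from compound 1 to compound 4 (beyond the scatter)), so the outcome of substituting this nitrogen depends on the group carried by the carbonyl. Nothing available explains the difference between these two groups.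

The change removes the nitrooxy group and brings in both bromine and a branched carbon chain at once, so the compounds shown cannot separate the contribution of the halogen from that of the chain; a plain ethyl or a 1-chloroethyl group on the same carbonyl carbon would divide the two. Also open, going by these compounds, is whether 1-bromoethyl keeps its effect on the core of compound 3, which carries 2,6-dichlorophenyl in place of 2,4-dimethoxyphenyl.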